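The source may report more compounds than this note shows. Statements on the series, on what has been measured and on what is new or still open speak of the compounds shown alone.

For the measured compounds named here, compound 1 `CCCCO/N=C/c1c(N)ncnc1Oc1ccc2[nH]c(C)cc2c1F` holds the lower of the two numbers measured so far: in a functional assay on A-375 cells (Homo sapiens) for antiproliferative activity (on this read-out higher numbers stand for weaker inhibition and lower numbers for stronger inhibition), compound 1 gives 446 nM. Going by the values given here, the other measured compound, compound 2 `Cc1cc2c(F)c(Oc3ncnc(N)c3/C=N/OCC3CCCCC3)ccc2[nH]1`, gives 4920 nM in this assay, and the change of an 11-fold higher number from compound 1 to compound 2 (1.04 log units; beyond the scatter) is the only measured step at this part of the molecule. Compound 3 `CCO/N=C/c1c(N)ncnc1Oc1ccc2[nH]c(C)cc2c1F` has not yet been measured. It differs from compound 1 by hydrogen in place of ethyl on a saturated chain carbon, two bonds along the chain from an oxygen on an unsaturated carbon, which, read one bond further out, is butyl to ethyl. Among the compounds with values here, the single step to compound 2 shows that making the chain at that place larger weakened inhibition strongly, but it runs in the opposite direction to the present change and says little about what a shorter chain does; compound 3 has no closer comparison among the measured compounds. Compound 3 is therefore expected to stay near compound 1, with an expected step of a 1.1-fold lower number from compound 1 to compound 3 (0.05 log units; within the scatter) in this assay. The value of compound 3 is estimated at 400 nM, with a range from 150 nM to 1200 nM.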

Compound 3, half-maximal inhibitory concentration: 27 nM
Compound 3: middle estimate off by 15-fold (1.17 log units), on the high side; measured number below the stated range.
By their numbers in this assay, from the lowest: compound 3; then compound 1; then compound 2.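

In this assay the change from butoxy to ethoxy gives a 17-fold lower number from compound 1 to compound 3 (1.22 log units; beyond the scatter) and so shows that this position responds strongly to shortening the chain, which the earlier step, an enlargement, could not show. With a 180-fold lower number from compound 2 to compound 3 (2.26 log units; beyond the scatter) as well, compound 3 stands as the most potent of the three compounds, and the number rises in the order ethoxy, butoxy, cyclohexyl-bearing chain, with none of the three going against that order. The material shown offers no measured evidence that would explain this sharp response to chain length.

The compounds shown leave open how sharply the number changes from one chain length to the next, and whether it would keep falling with a methoxy chain or rise again, while a propoxy chain would show whether the change from ethoxy to butoxy is gradual or abrupt. They also leave open how this position would respond to a branched chain such as isopropyl, or to a chain ending in a hydroxyl group, an amine or a carboxylic acid.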